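The source may hold more compounds than are shown below. What is called first, only, known or untested is meant among the compounds shown, and "the series" means these compounds.

Compound 1 `Cc1ccc(Nc2nc(C)c(C(=O)/C=C/c3ccc(Cl)cc3)s2)cc1` gives in a functional assay on PC-3 cells (Homo sapiens) for cytotoxicity, read by MTT assay (on this read-out lower numbers stand for stronger inhibition and higher numbers for weaker inhibition), only a limit, > 25000 nM.
Compound 2 `Cc1nc(Nc2cccc(Cl)c2)sc1C(=O)/C=C/c1ccc(Cl)cc1` gives in this assay only a limit, > 25000 nM.
Compound 3 `Cc1nc(Nc2ccc(Cl)c(Cl)c2)sc1C(=O)/C=C/c1ccc(Cl)cc1` gives in this assay only a limit, > 25000 nM.

Compound 3 therefore stands at the edge of what this assay can report, and no number separates it from the other two compounds: the limit of > 25000 nM in this assay, at which 3 of the 3 values shown sit. The measured steps tell nothing about size. a step that the two limits leave unreadable from compound 1 to compound 2, a step that the two limits leave unreadable from compound 1 to compound 3 and a step that the two limits leave unreadable from compound 2 to compound 3 all run from one limit to another. The step to compound 4 `Cc1cccc(Nc2nc(C)c(C(=O)/C=C/c3ccc(Cl)cc3)s2)c1` changes the group on the ring nitrogen: 3-methylphenyl in place of 3,4-dichlorophenyl on a nitrogen on an aromatic ring. Compound 1, which carries the 4-methylphenyl, gave only a limit, > 25000 nM. Compound 2, which carries the 3-chlorophenyl, also gave only a limit, > 25000 nM. Since both neighbouring patterns sit at the limit, the expected step from compound 3 to compound 4 is a step that the limit leaves unreadable from compound 3 to compound 4, meaning no readable change. Compound 4 is thus estimated at 30000 nM in this assay, between 12000 nM and 100000 nM, most likely again reported only as a limit.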

Compound 4, half-maximal inhibitory concentration: > 25000 nM
Compound 4: a limit, no number; the forecaster's own chance of this, stated with the estimate: 80%; the middle value lies beyond the limit too.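

Compound 4 sits at a limit, as do compound 1, compound 2 and compound 3, so none of the steps among them can be read: the limit of > 25000 nM in this assay, at which 4 of the 4 values shown sit. The compounds shown leave open which change to the shared core, if any, would in this assay give a real number rather than a limit.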